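A few compounds are considered here, and "the series" means these few. Any claim that something is new, unique, unknown or untested is made for them only; others in the source may bear on it.

Compound 1, `Oc1ccc(CNc2cc(C(F)(F)F)cc3[nH]ncc23)cc1`: 2550 nM in an assay for inhibition of Tryptophan 2,3-dioxygenase (Homo sapiens), with stated times of 10 min and 60 min; a lower number here means a stronger inhibitor, a higher number a weaker inhibitor
Compound 2, `FC(F)(F)c1cc(NC[C@H]2CCCCN2)c2cn[nH]c2c1`: 460 nM in this assay

Compound 2 stands lowest of the two numbers in this assay, with compound 1 giving the higher one. Compound 3, `FC(F)(F)c1cc(NCC2CNC2)c2cn[nH]c2c1`, is not yet measured. (azetidin-3-yl in place of piperidin-2-yl on a saturated chain carbon bound to a nitrogen on an aromatic ring). Going by the values given here, the only step seen so far is a 5.5-fold lower number from compound 1 to compound 2 (0.74 log units; beyond the scatter), which brought in the piperidin-2-yl group now being exchanged; it shows this position responds to change, but no step yet compares one saturated ring with another. A modest move toward a higher number is expected, a 2.0-fold higher number from compound 2 to compound 3 (0.29 log units; within the scatter). Compound 3 is therefore estimated at 900 nM, between 300 nM and 2700 nM.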

Compound 3, half-maximal inhibitory concentration: > 100000 nM
Compound 3 was reported as a limit; the forecaster's own chance of this, stated with the estimate: 5%; middle value at least 110-fold (2.04 log units) away from the limit.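

Compound 3 gives no number, only a limit of the assay: the limit of > 100000 nM in this assay, at which 1 of the 3 values shown sits. The earlier step showed that this position responds to change, but not how sharply one saturated ring can differ from another: azetidin-3-yl in place of piperidin-2-yl gives an at least 210-fold higher number from compound 2 to compound 3 (2.33 log units; beyond the scatter). The azetidine also falls well short of the 4-hydroxyphenyl group, with an at least 39-fold higher number from compound 1 to compound 3 (1.59 log units; beyond the scatter).

The two saturated rings differ in both size and point of attachment, and the compounds shown cannot separate these two differences. A pyrrolidin-3-yl or piperidin-3-yl group on the same chain carbon remains an open case.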